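A few compounds are considered here, and "the series" means these few. Any claim that something is new, unique, unknown or untested is made for them only; others in the source may bear on it.

Three analogues of the shared core have numbers in a functional assay on NCI-H460 cells (Homo sapiens) for cytotoxicity, read by MTT assay, with a stated time of 72 h (a higher number here means a weaker inhibitor, a lower number a stronger inhibitor), so far. Compound 1 `COc1ccc(OC)c(/C=N/NC(=O)Nc2ccc(Oc3ccnc(-c4nncn4CCN(C)C)c3)c(F)c2)c1` gives 2930 nM. Compound 2 `CN(C)CCn1cnnc1-c1cc(Oc2ccc(NC(=O)N/N=C/c3ccc(Cl)cc3)cc2F)ccn1` gives 320 nM, the lowest of the three. Compound 3 `CN(C)CCn1cnnc1-c1cc(Oc2ccc(NC(=O)N/N=C/c3cc(Br)c(O)c(Br)c3)cc2F)ccn1` gives 3760 nM. The steps between them sit on the aryl carbon with a double bond to nitrogen: a 9.2-fold lower number from compound 1 to compound 2 (0.96 log units; beyond the scatter), a 12-fold higher number from compound 2 to compound 3 (1.07 log units; beyond the scatter), and a 1.3-fold higher number from compound 1 to compound 3 (0.11 log units; within the scatter).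

Compound 4 `CN(C)CCn1cnnc1-c1cc(Oc2ccc(NC(=O)N/N=C/c3ccccc3)cc2F)ccn1` is the next point on the same aryl: hydrogen in place of chloro on an aromatic carbon of a six-membered aromatic ring of carbon only, para to a large group. Both measured steps from compound 2 went upward when its 4-chlorophenyl was exchanged, so the aryl substituent is a sensitive place in this assay. Losing the chloro alone is a smaller change than either exchange, so a modest upward step is expected, a 2.8-fold higher number from compound 2 to compound 4 (0.45 log units; beyond the scatter). Compound 4 is therefore estimated at 900 nM, with a range of 300 nM to 3000 nM.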

Compound 4, half-maximal inhibitory concentration: 1780 nM
The estimate for compound 4 lay 2.0-fold (0.30 log units) below the measured number, and the stated range covers the measured number.
By their numbers in this assay, from the lowest: compound 2; then compounds 4, 1 and 3 (each within the scatter of the next, the first and the last beyond it).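

Compound 4 gives the series its unsubstituted phenyl as a reference in this assay, and taking off the single chloro gives a 5.6-fold higher number from compound 2 to compound 4 (0.75 log units; beyond the scatter). Against that phenyl, the 2,5-dimethoxyphenyl does not separate, with a 1.6-fold lower number from compound 1 to compound 4 (0.22 log units; within the scatter), while the 3,5-dibromo-4-hydroxyphenyl does, with a 2.1-fold lower number from compound 3 to compound 4 (0.32 log units; beyond the scatter). Substitution on this aryl therefore has no single direction: 4-chlorophenyl lies on the low side of phenyl, 3,5-dibromo-4-hydroxyphenyl lies on the high side, and 2,5-dimethoxyphenyl cannot be told apart from phenyl.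

Whether the low number is particular to chloro remains open, as the compounds shown carry no fluoro, methyl or nitrile on that same aromatic carbon. No measurement at hand accounts for any of these steps.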